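This account rests on a few compounds, and the source may have more. Where it says the series, first, only, none or still open, it means among the compounds named here.

Compound 1 `CCCc1nn(C)c2c(NCc3ccc(F)cc3)nc(/C=C/c3cccnc3)nc12` — in a functional assay on L02 cells (Homo sapiens) for inhibition, read by Griess assay, with stated times of 1 h and 24 h (on this read-out lower numbers stand for stronger inhibition and higher numbers for weaker inhibition), compound 1 gives 940000 nM.
Compound 2 `COc1cc(/C=C/c2nc(N3CCCC3)c3sccc3n2)cc(OC)c1OC` — in this assay compound 2 gives 681000 nM.
Compound 3 `CCN1CCN(c2nc(/C=C/c3cc(OC)c(OC)c(OC)c3)nc3ccsc23)CC1` — in this assay compound 3 gives only a limit, > 1000000 nM.

All three measured compounds sit at the weak end of the scale, and compound 3 sits on the limit itself, as recorded in the limit of > 1000000 nM in this assay, at which 1 of the 3 values shown sits, so for compound 3 only a bound and no number is known. For the measured compounds named here, the single measured step that touches compound 3 is an at least 1.4-fold higher number from compound 2 to compound 3 (0.16 log units; that floor lies within the scatter), a step whose floor lies within the usual scatter.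

Compound 4 `COc1cc(/C=C/c2nc(N(C)c3ccccc3)c3sccc3n2)cc(OC)c1OC` differs from compound 3 in one place: methyl(phenyl)amino in place of 4-ethylpiperazin-1-yl on an aromatic carbon. Going by the values given here, no measured pair shows this exchange, and the only step involving compound 3 is itself undecided, so nothing in the data points in either direction beyond the scatter. Compound 4 is therefore expected to remain in the same weak region, and the expected step of an at least 1.2-fold lower number from compound 3 to compound 4 (0.09 log units; that floor lies within the scatter) is small. Compound 4 is estimated at 800000 nM, with a range from 300000 nM to 2000000 nM.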

Compound 4, half-maximal inhibitory concentration: 767000 nM
For compound 4 the middle estimate is 1.0-fold (0.02 log units) above the measured one; the measured number falls inside the stated range.
By their numbers in this assay, from the lowest: compounds 2, 4 and 1 (each within the scatter of the next). At a limit, above all of these: compound 3.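

Against pyrrolidin-1-yl, methyl(phenyl)amino on this aromatic carbon gives a 1.1-fold higher number from compound 2 to compound 4 (0.05 log units; within the scatter) in this assay, so bringing in a six-membered aromatic ring of carbon only does not move the number beyond the scatter. Against 4-ethylpiperazin-1-yl, the same group gives an at least 1.3-fold lower number from compound 3 to compound 4 (0.11 log units; that floor lies within the scatter), and the true size of this step stays unknown because one end of it is a limit: the limit of > 1000000 nM in this assay, at which 1 of the 4 values shown sits. Neither exchange at this place therefore shows a change beyond the scatter.

The compounds shown leave open whether any other group at this place, such as a primary amine or morpholin-4-yl, would bring the number down beyond the scatter. They also leave open how far compound 3 lies beyond its limit.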